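The compounds below may be only part of what the source reports. "The series", "measured", "known", "first", "only" and "open" are said of these compounds alone.

Measured compounds in an in vitro assay on HEK385-7 cells for displacement of a labelled ligand from prostaglandin D2 receptor 2 (Homo sapiens); a higher number here means a weaker inhibitor, a lower number a stronger inhibitor:
compound 1 `O=C(O)Cc1sc(C(c2ccccc2)c2ccccc2)nc1-c1ccccc1`: 570 nM
compound 2 `COc1cc(-c2nc(C(c3ccc(F)cc3)c3ccc(F)cc3)sc2CC(=O)O)ccn1`: 29 nM
compound 3 `O=C(O)Cc1sc(C(c2ccccc2)c2ccccc2)nc1-c1ccc(F)cc1`: 8.7 nM

Compound 2 holds the second highest of the three numbers in this assay: compound 3 sits at a lower number, by a gap beyond the scatter, and compound 1 at a higher one, also beyond the scatter. For the measured compounds named here, the only one-place step among the measured compounds is a 66-fold lower number from compound 1 to compound 3 (1.82 log units; beyond the scatter), a fluoro in place of hydrogen on an aromatic carbon. Going by the values given here, compound 2 differs from both of the others in more than one place, so no single step connects it to either.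

Compound 4 `O=C(O)Cc1sc(C(c2ccc(F)cc2)c2ccc(F)cc2)nc1-c1ccnc(O)c1` differs from compound 2 by hydrogen in place of methyl on an oxygen on an aromatic ring, that is methoxy to hydroxy, 2-methoxypyridin-4-yl to 2-hydroxypyridin-4-yl. Among the compounds with values here, none of the measured steps touches this oxygen; the single step known concerns a fluoro on an aromatic carbon and gives no guide to a methyl leaving an oxygen. Within the data shown here, with no comparable step, no direction can be derived, and the expectation for this assay is a step not beyond the scatter, carried with wide uncertainty. Compound 4 is therefore estimated near 40 nM, within the range 10 nM to 160 nM. The step this estimate means, a 1.4-fold higher number from compound 2 to compound 4 (0.14 log units; within the scatter), is expected to stay inside the scatter.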

Compound 4, half-maximal inhibitory concentration: 68 nM
For compound 4 the middle estimate is 1.7-fold (0.23 log units) below the measured one, within the range that was stated.
By their numbers in this assay, from the lowest: compound 3; then compound 2; then compound 4; then compound 1.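

In this assay, for the compounds shown here, the methyl on the oxygen of the 2-methoxypyridin-4-yl group is not a silent position: methoxy to hydroxy gives a 2.3-fold higher number from compound 2 to compound 4 (0.37 log units; beyond the scatter), the first measured change at this oxygen. Going by these compounds alone, the step is modest, whereas the only other one-place step, a 66-fold lower number from compound 1 to compound 3 (1.82 log units; beyond the scatter), is large and lies at a different place, so a change at this oxygen moves the number by a smaller amount in this one example. No measurement accompanying these compounds bears on why the number rises when the methyl leaves, and the step stands as an observation only.

Going by these compounds, whether the step follows from the hydroxy group itself or from the loss of the methyl stays open, and an ethyl or a longer alkyl chain on this oxygen, or an amine in its place, would help to separate these two readings. Also open, on these data alone, is whether the same step would appear on the core of compound 3, since the methoxy to hydroxy change is seen here only with the two fluoro-bearing aromatic rings of compound 2 and compound 4.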